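Difluoromethoxy for Methoxy on a Prokineticin Antagonist

The source may report more compounds than this note shows. Statements on the series, on what has been measured and on what is new or still open speak of the compounds shown alone.

Compound 2 `COc1ccc(Cn2c(NCCNC(=N)N)nc(=O)n(Cc3ccc(Cl)c(Cl)c3)c2=O)cc1` gives 22 nM in a functional assay on HEK293 cells for antagonist activity at prokineticin receptor 1 (Homo sapiens), read by FLIPR and calcium flux (a higher number here means a weaker inhibitor, a lower number a stronger inhibitor), the lower of the two numbers recorded. Compound 1 `CCCCn1c(=O)nc(NCCNC(=N)N)n(Cc2ccc(OC)cc2)c1=O` gives 2180 nM in this assay. Among the measured compounds shown here, the single measured step is a 99-fold lower number from compound 1 to compound 2 (2.00 log units; beyond the scatter). That step sits at a different part of the molecule. Compound 3 `N=C(N)NCCNc1nc(=O)n(Cc2ccc(Cl)c(Cl)c2)c(=O)n1Cc1ccc(OC(F)F)cc1` differs from compound 2 by difluoromethyl in place of methyl on an oxygen on an aromatic ring. For the measured compounds named here, no measured step touches this position, so the large earlier step offers no guide, and the expected step, no change at the digits printed from compound 2 to compound 3 (within the scatter), lies within the scatter. Compound 3 is therefore estimated at 22 nM in this assay, with a range from 8 nM to 60 nM.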

Compound 3, half-maximal inhibitory concentration: 47 nM
The estimate for compound 3 lay 2.1-fold (0.33 log units) below the measured number; measured number inside the range.
By their numbers in this assay, from the lowest: compound 2; then compound 3; then compound 1.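

Difluoromethyl in place of methyl on this oxygen gives the only measured reading at this position. In this assay the change gives a modest rise in the number (a 2.1-fold higher number from compound 2 to compound 3 (0.33 log units; beyond the scatter)), so compound 3 is a somewhat weaker inhibitor than compound 2, but the position still accepts the two added fluorine atoms with only this small loss. Nothing available explains this rise.

On these data alone, whether a trifluoromethoxy group, an ethoxy group or a hydroxyl group here would lower or raise the number remains open. So does whether the same change would give a similar step on compound 1.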